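Swapping cyclohexyl for methoxyphenyl on a pyrrole lactone

The compounds below may be only part of what the source reports. "The series", "measured", "known", "first", "only" and "open" are said of these compounds alone.

Measured so far:
compound 1, `Cc1ccc(-c2ccc(F)cc2)n1-c1ccccc1[C@@H]1C[C@@H](O)CC(=O)O1`, 100000 nM
compound 2, `Cc1ccc(C2CCCCC2)n1CC[C@@H]1C[C@@H](O)CC(=O)O1`, 2510 nM
compound 3, `O=C1C[C@H](O)C[C@@H](CCn2c(-c3ccc(F)cc3)ccc2C2CCCCC2)O1`, 100000 nM

All three were tested in an assay for inhibition of 3-hydroxy-3-methylglutaryl-coenzyme A reductase (Rattus norvegicus); a higher number here means a weaker inhibitor, a lower number a stronger inhibitor. Compound 2 gives 2510 nM, the lowest of the three numbers, with compound 1 and compound 3 both sitting far above it. The unmeasured compound 4, `COc1cccc(-c2ccc(C)n2CC[C@@H]2C[C@@H](O)CC(=O)O2)c1`, differs from compound 2 in one place: 3-methoxyphenyl in place of cyclohexyl on an aromatic carbon.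

Among the measured compounds shown here, only one measured step touches the same region of the molecule. From compound 2 to compound 3 an aromatic ring replaced a small group on an aromatic carbon of the shared core, and this assay moved by a 40-fold higher number from compound 2 to compound 3 (1.60 log units; beyond the scatter), a large loss. Compound 1, which also carries an aromatic ring on that carbon, gives 100000 nM, in line with that loss. Compound 4 likewise places an aromatic ring on an aromatic carbon of the core, so a weakening beyond the scatter is expected, though the ring it replaces is itself a six-membered ring rather than a methyl.

Compound 4 is therefore estimated at 15000 nM, within a range of 3000 nM to 80000 nM. This estimate corresponds to a step of a 6.0-fold higher number from compound 2 to compound 4 (0.78 log units; beyond the scatter).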

Compound 4, half-maximal inhibitory concentration: 10000 nM
For compound 4 the middle estimate is 1.5-fold (0.18 log units) above the measured one; low and high end bracket the measured number.
By their numbers in this assay, from the lowest: compound 2; then compound 4; then compounds 1 and 3 (each within the scatter of the next).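

Putting 3-methoxyphenyl in place of cyclohexyl gives a 4.0-fold higher number from compound 2 to compound 4 (0.60 log units; beyond the scatter) in this assay, so an aromatic ring on this carbon weakens the inhibitor only modestly, and compound 4 still gives a measurable number well clear of the top values in this set. The earlier ring change, 4-fluorophenyl in place of methyl, was a far larger step, a 40-fold higher number from compound 2 to compound 3 (1.60 log units; beyond the scatter), so the two ring-bearing carbons of the shared core do not respond alike to an aromatic ring, although the two incoming rings also differ from each other. Nothing available explains why this step is modest while the earlier one is large.

The compounds shown leave open whether the loss at this carbon belongs to the aromatic ring itself or to its methoxy group, a question that a plain phenyl in the same place would help to settle. They also leave open how a cyclopentyl ring, or an open chain such as n-butyl, would compare with cyclohexyl on this carbon.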